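A few compounds are considered here, and "the series" means these few. Any claim that something is new, unique, unknown or untested is made for them only; others in the source may bear on it.

Measured in an ADME assay on Huh-7 cells (Homo sapiens) for cytotoxicity, read by XTT assay, with a stated time of 3 days, tested at 200 uM; on this read-out lower numbers stand for a stronger effect and higher numbers for a weaker effect at the one concentration tested:
compound 1, `Fc1ccc2nc(-c3cc(-c4ccccc4)nn3-c3ccccc3)ccc2c1`: 98.3%
compound 2, `Fc1ccc(-n2nc(-c3ccccc3)cc2-c2ccc3cc(F)ccc3n2)cc1`: 91.6%
compound 3, `Fc1ccc(-c2cc(-c3ccc4cc(F)ccc4n3)n(-c3ccc(F)cc3)n2)cc1`: 86.5%

Compound 2 stands second highest of the three numbers. Its nearest neighbour is compound 3, at a number 5.1 percentage points lower from compound 2 to compound 3 (within the scatter), and the furthest is compound 1, at a number 6.7 percentage points lower from compound 1 to compound 2 (within the scatter); both steps lie within the scatter, so the three compounds read as one level in this assay.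

Compound 4, `COc1ccc(-n2nc(-c3ccccc3)cc2-c2ccc3cc(F)ccc3n2)cc1`, differs from compound 2 by methoxy in place of fluoro on an aromatic carbon. Among the compounds with values here, no measured step exchanges a fluoro for a methoxy. The two steps at hand, a number 6.7 percentage points lower from compound 1 to compound 2 (within the scatter) and a number 5.1 percentage points lower from compound 2 to compound 3 (within the scatter), each place a fluoro on an aromatic carbon of this core, and both stay within the scatter. They bear on the present step only by showing that a single change on one of the aromatic rings has not moved this assay beyond the scatter so far. No step beyond the scatter is therefore expected in this assay, in either direction.

Compound 4 is expected at 90%, in the range 75% to 100%. The step this estimate means is a number 1.6 percentage points lower from compound 2 to compound 4 (within the scatter), expected to stay within the scatter.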

Compound 4, a percentage reported as activity, at one concentration (the size of the read-out at that concentration, not a potency): 97.4%
For compound 4 the middle estimate is 7.4 percentage points below the measured one; the range from low to high includes it.
By their numbers in this assay, from the lowest: compounds 3, 2, 4 and 1 (each within the scatter of the next, the first and the last beyond it).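

In this assay, the change from 4-fluorophenyl to 4-methoxyphenyl gives a number 5.8 percentage points higher from compound 2 to compound 4 (within the scatter), and methoxy in place of hydrogen at the same place, para to a large group, gives a number 0.9 percentage points lower from compound 1 to compound 4 (within the scatter). The earlier compounds shown here showed this place only with hydrogen and fluoro; it now also carries methoxy, with its two heavy atoms and one hydrogen-bond acceptor, and neither step leaves the scatter. Nothing measured here speaks to what lies behind these readings.

From the compounds shown here alone, whether an amine, a carboxylic acid or a longer alkoxy chain at this place would give a step beyond the scatter in this assay remains open. Also open, going by these compounds, is whether methoxy on the other phenyl ring of the shared core would read the same way.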